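Moving the pyridine one carbon out from the amide carbonyl

A few compounds are considered here, and "the series" means these few. Any claim that something is new, unique, unknown or untested is made for them only; others in the source may bear on it.

Compound 3 `COc1ccc(Cn2c(CCc3ccccc3)nnc2[C@H](NC(=O)c2ccccn2)c2c[nH]c3ccccc23)cc1` gives the lowest number of the three measured compounds in a functional assay on CHO cells for antagonist activity at growth hormone secretagogue receptor type 1 (Homo sapiens) (on this read-out lower numbers stand for stronger inhibition and higher numbers for weaker inhibition), at 12 nM. Compound 1 `COc1ccc(Cn2c(CCc3ccccc3)nnc2[C@H](NC(=O)c2ccccn2)c2c[nH]c3ccccc23)c(OC)c1` gives 25 nM and compound 2 `COc1ccc(-n2c(CCc3ccccc3)nnc2[C@H](NC(=O)c2ccccn2)c2c[nH]c3ccccc23)c(OC)c1` gives 65 nM; the steps of a 2.1-fold lower number from compound 1 to compound 3 (0.32 log units; beyond the scatter) and a 5.4-fold lower number from compound 2 to compound 3 (0.73 log units; beyond the scatter) both concern the group on the aromatic nitrogen of the shared core. Compound 4 `COc1ccc(Cn2c(CCc3ccccc3)nnc2[C@H](NC(=O)Cc2ccccn2)c2c[nH]c3ccccc23)cc1` differs from compound 3 in another place: (pyridin-2-yl)methyl in place of pyridin-2-yl on a carbonyl carbon. For the measured compounds named here, no measured step touches the amide side of the molecule, so the earlier steps give no direct guide to the size or direction of this change. In the absence of precedent, a modest loss is expected, a step of a 2.5-fold higher number from compound 3 to compound 4 (0.40 log units; beyond the scatter). Compound 4 is therefore estimated at 30 nM, within a range of 8 nM to 120 nM.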

Compound 4, antagonist equilibrium constant: 6 nM
Beside the measured number, compound 4's estimate is 5.0-fold (0.70 log units) above it, outside the stated range (below it).
By their numbers in this assay, from the lowest: compounds 4 and 3 (each within the scatter of the next); then compound 1; then compound 2.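

In this assay, for the compounds shown here, the first measured step on the amide side reads a 2.0-fold lower number from compound 3 to compound 4 (0.30 log units; within the scatter), so the two compounds cannot be told apart on this read-out. The pyridine ring can therefore sit one carbon further out from the carbonyl, as (pyridin-2-yl)methyl, with potency retained in this pair. Nothing shown explains this result.

Still open, as far as these compounds go, is how this position responds to a longer chain, or to an amine or a carboxylic acid in place of the pyridine ring. From the compounds shown here alone, it is also open whether the same swap behaves alike with the other nitrogen groups of compound 1 and compound 2.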